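This account rests on a few compounds, and the source may have more. Where it says the series, first, only, none or still open, it means among the compounds named here.

Series notes. Among the measured compounds shown here, in a functional assay on A549 cells (Homo sapiens) for inhibition, read by MTT assay, with a stated time of 48 h (a higher number here means a weaker inhibitor, a lower number a stronger inhibitor), compound 1 `COc1ccc(N(C)c2nc(C)nc3ccccc23)cc1C(=O)NCC[Se]C#N` gives 187 nM, the highest of the three numbers measured so far. Compound 2 `C[Se]c1ccc(N(C)c2nc(C)nc3ccccc23)cc1C` gives 2 nM and compound 3 `Cc1nc(N(C)c2ccc([Se]C#N)c(F)c2)c2ccccc2n1` gives 4 nM; both lie well below compound 1 by gaps beyond the usual scatter, so compound 1 is the weakest inhibitor of the three measured. Compound 4 `COc1ccc(N(C)c2nc(C)nc3ccccc23)cc1C(=O)OCC[Se]C#N` has not yet been measured. Relative to compound 1, the change at the carbonyl carbon is a group of 6 heavy atoms (3 carbon, 1 nitrogen, 1 oxygen, 1 selenium; no ring) in place of a group of 6 heavy atoms (3 carbon, 2 nitrogen, 1 selenium; no ring), on a carbonyl carbon. For the measured compounds named here, no measured pair in the set shows this change, so no step size is available from the data. The expectation is a step from compound 1 to compound 4 of about a 1.1-fold higher number from compound 1 to compound 4 (0.03 log units; within the scatter), not beyond the scatter. Compound 4 is estimated at 200 nM, with a range of 60 nM to 650 nM.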

Compound 4, half-maximal inhibitory concentration: 353 nM
The estimate for compound 4 lay 1.8-fold (0.25 log units) below the measured number; the measured number falls inside the stated range.
By their numbers in this assay, from the lowest: compounds 2 and 3 (each within the scatter of the next); then compounds 1 and 4 (each within the scatter of the next).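

On a carbonyl carbon, a group with 1 hydrogen-bond donor and 1 hydrogen-bond acceptor gives way to one with 0 hydrogen-bond donors and 2 hydrogen-bond acceptors, and this assay shows a 1.9-fold higher number from compound 1 to compound 4 (0.28 log units; within the scatter) with the two compounds not separated. In this single pair, then, the hydrogen-bond donor of compound 1 is not required to keep the reading of compound 1 at this position. No measurement available here explains why the two compounds read alike.

Going by these compounds, whether a carboxylic acid or a longer chain on this carbonyl carbon would also read alike stays open. So does whether any group at this position can bring the number down towards those of compound 2 and compound 3.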